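Two Fluorophenyl-to-Dichlorophenyl Swap on the Shared Core

This account rests on a few compounds, and the source may have more. Where it says the series, first, only, none or still open, it means among the compounds named here.

Compound 1 `C=CCn1c(=O)/c(=C\c2cccc(F)c2)[nH]c(=O)/c1=C\c1ccccc1OC` serves as the starting point. In a functional assay on NCI-H1975 cells (Homo sapiens) for cytotoxicity, read by CCK-8 assay, with a stated time of 72 h (on this read-out lower numbers stand for stronger inhibition and higher numbers for weaker inhibition), compound 1 gives 25600 nM, the highest of the two numbers in hand. Compound 3 `COc1ccccc1/C=c1/[nH]c(=O)/c(=C\c2nc[nH]c2C(C)(C)C)[nH]c1=O`, which carries a different core and different substituents, gives 100 nM in this assay, a much lower number that lies beyond the scatter. Compound 2 `C=CCn1c(=O)/c(=C\c2cc(OC)c(OC)c(OC)c2)[nH]c(=O)/c1=C\c1cccc(Br)c1` is reported in this assay only as "not active" (no number reported), so no number stands against it, and compounds 1 and 2 share the allyl group and the core but differ in both aryl groups.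

Compound 4 `C=CCn1c(=O)/c(=C\c2ccc(Cl)c(Cl)c2)[nH]c(=O)/c1=C\c1ccccc1OC` is the compound not yet measured. It differs from compound 1 by 3,4-dichlorophenyl in place of 3-fluorophenyl on a double-bonded chain carbon bound to an aromatic carbon. Going by the values given here, no pair of measured compounds differing only in this way is in hand, so the size of the step has to be inferred from the spread of the numbers alone. Compound 2, with a bromine on one aryl group, gives no number at all, which speaks against a large gain from another halogenated aryl group. Compound 4 is therefore expected to land close to compound 1, with a step of a 1.2-fold lower number from compound 1 to compound 4 (0.07 log units; within the scatter) estimated at none beyond the scatter. The value of compound 4 in this assay is estimated at 22000 nM, within a range from 7000 nM to 70000 nM.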

Compound 4, half-maximal inhibitory concentration: "not active" (no number reported)
No number was reported for compound 4; no gap can be computed for the estimate.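

Going by these compounds alone, compound 4 is reported in this assay as "not active" (no number reported) and so offers no step from compound 1 that can be read. No measured property on hand bears on this result. The compounds shown leave open how far 3,4-dichlorophenyl in place of 3-fluorophenyl moves the value on the shared core.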